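The source may report more compounds than this note shows. Statements on the series, on what has been measured and on what is new or still open speak of the compounds shown alone.

Compound 1 `Cc1cc(-n2cccc2)cn2c(CSCCc3ccccc3)cnc12` is measured in an ADME assay on HEL cells (Homo sapiens) for cytotoxicity, with a stated time of 3 days (on this read-out lower numbers stand for higher toxicity in this test and higher numbers for lower toxicity in this test), and gives 11 ug/mL. Compound 2 `Cc1cc(-n2ccnc2)cn2c(CSCCc3ccccc3)cnc12` carries the change 1H-imidazol-1-yl in place of 1H-pyrrol-1-yl on an aromatic carbon and gives 23 ug/mL in this assay; the step of a 2.1-fold higher number from compound 1 to compound 2 (0.32 log units; beyond the scatter). Compound 3 `Cc1cc(-n2cccc2)c2ncc(CSCCc3ccccc3)n2c1` has the same atoms as compound 1 joined differently, and the difference between the two cores is not broken down here; in this assay compound 3 gives 26 ug/mL. Compound 4 `Cc1cc(-n2ccnc2)c2ncc(CSCCc3ccccc3)n2c1` differs from compound 3 by 1H-imidazol-1-yl in place of 1H-pyrrol-1-yl on an aromatic carbon, the same kind of change as that from compound 1 to compound 2, though here the place is ortho to a fused ring rather than para to a fused ring. Within the data shown here, compound 4 is expected to show a step of a 1.9-fold higher number from compound 3 to compound 4 (0.28 log units; within the scatter), resting on the single earlier step of a 2.1-fold higher number from compound 1 to compound 2 (0.32 log units; beyond the scatter). Compound 4 is therefore estimated at 50 ug/mL, between 25 ug/mL and 100 ug/mL.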

Compound 4, half-maximal cytotoxic concentration: 10 ug/mL
Beside the measured number, compound 4's estimate is 5.0-fold (0.70 log units) above it, outside the stated range (below it).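

On the core of compound 3, 1H-imidazol-1-yl in place of 1H-pyrrol-1-yl gives a 2.6-fold lower number from compound 3 to compound 4 (0.41 log units; beyond the scatter) in this assay, so the change does not carry over from the core of compound 1 and runs the opposite way: the same change on two cores in this assay, a 2.1-fold higher number (0.32 log units; beyond the scatter) from compound 1 to compound 2 and a 2.6-fold lower number (0.41 log units; beyond the scatter) from compound 3 to compound 4, 5.4-fold (0.74 log units) apart, beyond the scatter of two such steps

In this series, then, neither the size nor the direction of the step on one core predicts the step on the other. Among these compounds, with only one pair on each core, this does not show why the cores differ or whether the opposite directions would hold elsewhere.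

From the compounds shown here alone, it remains open whether an amine or a carboxylic acid at this place would also behave differently on the two cores. Also open, going by these compounds, is whether the opposite directions would persist with a chlorine atom in place of the methyl group.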